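Thiophene series: methoxy to hydroxy step carried to a second core

The source may report more compounds than this note shows. Statements on the series, on what has been measured and on what is new or still open speak of the compounds shown alone.

Measured compounds:
compound 1 `COc1ccc(C(=O)NNC(=S)Nc2csc(-c3ccc(C)cc3)c2)cc1`, 11000 nM
compound 2 `Cc1ccc(-c2cc(NC(=S)NNC(=O)c3ccc(O)cc3)cs2)cc1`, 44000 nM
compound 3 `COc1ccc(-c2nnc(Nc3csc(-c4ccccc4)c3)s2)cc1`, 8000 nM

In a functional assay on A549 cells (Homo sapiens) for inhibition, read by colorimetric assay and MTT assay, with a stated time of 72 h (a higher number here means a weaker inhibitor, a lower number a stronger inhibitor), compound 1 gives 11000 nM, while compound 2 gives 44000 nM. The two differ in one place, (hydrogen in place of methyl on an oxygen on an aromatic ring), and the step is a 4.0-fold higher number from compound 1 to compound 2 (0.60 log units; beyond the scatter). Compound 3 is built on a different core; the difference between the two cores is not broken down here. In this assay compound 3 gives 8000 nM, which lies within the scatter of compound 1 and beyond it from compound 2.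

Compound 4 `Oc1ccc(-c2nnc(Nc3csc(-c4ccccc4)c3)s2)cc1` is not yet measured. It stands to compound 3 as compound 2 stands to compound 1: the change is hydrogen in place of methyl on an oxygen on an aromatic ring, at a place described in the same words in both pairs, so it is taken as the same change. If it carries over to the core of compound 3, the expected step in this assay is a 4.0-fold higher number from compound 3 to compound 4 (0.60 log units; beyond the scatter), resting on the single earlier observation a 4.0-fold higher number from compound 1 to compound 2 (0.60 log units; beyond the scatter). Compound 4 is therefore expected to give about 32000 nM in this assay, with a plausible range of 12000 nM to 80000 nM.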

Compound 4, half-maximal inhibitory concentration: 15000 nM
Compound 4: the middle estimate sits 2.1-fold (0.33 log units) above what was measured; low and high end bracket the measured number.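

In this assay the methoxy to hydroxy change on the second core gives a 1.9-fold higher number from compound 3 to compound 4 (0.27 log units; within the scatter), so on that core the step cannot be told apart from repeat measurement. Set beside the earlier step, the two readings do not separate: the same change on two cores in this assay, a 4.0-fold higher number (0.60 log units; beyond the scatter) from compound 1 to compound 2 and a 1.9-fold higher number (0.27 log units; within the scatter) from compound 3 to compound 4, 2.1-fold (0.33 log units) apart, within the scatter of two such steps. Within the data shown here, the series therefore gives no sign that the change behaves differently on the two cores, but it does not establish that the change carries over unchanged, as there is only one pair per core and the step lies beyond the scatter on one core only.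

The compounds shown leave open whether an amine or a carboxylic acid in place of the hydroxy group on the same aromatic ring would give a step beyond the scatter on either core. Also open, as far as these compounds go, is whether a longer chain on the oxygen, such as ethoxy, would read like methoxy on both cores.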